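Swapping the anilino ring's halogen in a weakly cytotoxic series

The source may hold more compounds than are shown below. What is called first, only, known or untested is meant among the compounds shown, and "the series" means these compounds.

Three compounds share one core and differ only in the ring carried on the nitrogen attached to the aromatic system. Compound 1 `Fc1ccc(Nc2nc(-c3cccc(F)c3)nc3ccc(F)cc23)cc1` carries a 4-fluorophenyl there. In a functional assay on U-937 cells (Homo sapiens) for cytotoxicity, read by MTT assay, with a stated time of 48 h (on this read-out lower numbers stand for stronger inhibition and higher numbers for weaker inhibition), compound 1 reaches only the limit > 50000 nM. Compound 2 `Fc1cccc(-c2nc(Nc3cccc(Cl)c3)c3cc(F)ccc3n2)c1` carries a 3-chlorophenyl. In this assay compound 2 likewise stops at the limit > 50000 nM. Compound 3 `Fc1cccc(-c2nc(Nc3ccccc3Cl)c3cc(F)ccc3n2)c1` carries a 2-chlorophenyl. In this assay compound 3 also gives only the limit > 50000 nM. Because (the limit of > 50000 nM in this assay, at which 3 of the 3 values shown sit), the steps a step that the two limits leave unreadable from compound 1 to compound 3 and a step that the two limits leave unreadable from compound 2 to compound 3 cannot be sized.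

Compound 4 `Fc1cccc(-c2nc(Nc3ccc(Br)cc3)c3cc(F)ccc3n2)c1` is unmeasured. It differs from compound 3 by 4-bromophenyl in place of 2-chlorophenyl on a nitrogen on an aromatic ring. The measured steps at this same nitrogen, a step that the two limits leave unreadable from compound 1 to compound 2, a step that the two limits leave unreadable from compound 1 to compound 3 and a step that the two limits leave unreadable from compound 2 to compound 3, all bear on this change, yet each is unreadable. Among the compounds with values here, no direction for the step that the limit leaves unreadable from compound 3 to compound 4 can therefore be expected beyond the scatter; compound 4 is expected most likely to stop at the same limit. For compound 4 the estimate in this assay is 60000 nM, within 20000 nM to 200000 nM.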

Compound 4, half-maximal inhibitory concentration: > 50000 nM
Compound 4: a limit, no number; the forecaster's own chance of this, stated with the estimate: 85%; the middle value is on the limit's open side.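

In this assay compound 4 gives only a limit, > 50000 nM. Within the data shown here, no step from compound 1, compound 2 or compound 3 to compound 4 can be read: the limit of > 50000 nM in this assay, at which 4 of the 4 values shown sit.

Going by these compounds, how far these four rings on the nitrogen differ in cytotoxicity stays open.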